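Pyridyl urea series: nitrile pyridine replaced by chloro-methyl pyridine

A few compounds are considered here, and "the series" means these few. Any claim that something is new, unique, unknown or untested is made for them only; others in the source may bear on it.

Compound 2 `CCOc1cc(NC(=O)NCc2cc(C)c(-c3cn(C)nc3C(F)(F)F)nn2)cc(C#N)n1` gives 11000 nM in a functional assay on CHO cells for antagonist activity at sphingosine 1-phosphate receptor 2 (Homo sapiens), read by fluorescence and calcium flux, with a stated time of 3 min (on this read-out lower numbers stand for stronger inhibition and higher numbers for weaker inhibition), the highest of the three numbers in hand. Compound 3 `CCOc1nc(C#N)cc(NC(=O)NCc2cc(C)c(-c3cn(C)nc3C(F)(F)F)nn2)c1C` gives 7100 nM; the step of a 1.5-fold lower number from compound 2 to compound 3 (0.19 log units; within the scatter). Compound 1 `CCOC(=O)c1cc(C)cc(NNC(=O)Nc2cc(Cl)nc(Cl)c2)n1` gives 760 nM, a clearly lower number than compound 2.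

Compound 4 `CCOc1nc(C)cc(NC(=O)NCc2cc(C)c(-c3cn(C)nc3C(F)(F)F)nn2)c1Cl` differs from compound 2 by 3-chloro-2-ethoxy-6-methylpyridin-4-yl in place of 2-cyano-6-ethoxypyridin-4-yl on an amide-type nitrogen. Among the measured compounds shown here, no measured step reworks this ring in the same way; the nearest precedent, a 1.5-fold lower number from compound 2 to compound 3 (0.19 log units; within the scatter), puts a methyl on an aromatic carbon and stays within the scatter. On that thin basis no step beyond the scatter is expected in this assay, in either direction.

Compound 4 is therefore expected near 8000 nM, within a range of 2500 nM to 25000 nM. The expected step of a 1.4-fold lower number from compound 2 to compound 4 (0.14 log units; within the scatter) is accordingly small.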

Compound 4, half-maximal inhibitory concentration: 8700 nM
Beside the measured number, compound 4's estimate is 1.1-fold (0.04 log units) below it; low and high end bracket the measured number.
By their numbers in this assay, from the lowest: compound 1; then compounds 3, 4 and 2 (each within the scatter of the next).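

Replacing 2-cyano-6-ethoxypyridin-4-yl with 3-chloro-2-ethoxy-6-methylpyridin-4-yl on the amide-type nitrogen gives a 1.3-fold lower number from compound 2 to compound 4 (0.10 log units; within the scatter) in this assay. Compound 3 keeps the nitrile, whereas compound 4 shows that the nitrile can leave, with chlorine and methyl entering, without a step beyond the scatter. No supporting measurement bears on this result.

Going by these compounds, whether an amine or a carboxylic acid on this ring would move the number beyond the scatter stays open. On these data alone, the separate contributions of the chlorine and the methyl also stay open.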